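Methyl Removal from Compound 2: Expected Cytotoxicity

A few compounds are considered here, and "the series" means these few. Any claim that something is new, unique, unknown or untested is made for them only; others in the source may bear on it.

Of the compounds shown here, three of a shared core have been measured. Compound 1 `Cc1ccc(-c2c(C)c(-c3ccc(C)c(C)c3)c(C(OC(C)(C)C)C(=O)O)c(C)c2N)cc1C` gives 12000 nM in an ADME assay on MT4 cells (Homo sapiens) for cytotoxicity, read by MTT assay, with a stated time of 4 days; a higher number here means that more compound is tolerated, a lower number that less compound is tolerated. Compound 3 `CC(=O)Nc1c(C)c(C(OC(C)(C)C)C(=O)O)c(-c2ccc(C)c(C)c2)c(C)c1-c1ccc(C)c(C)c1` gives 19000 nM in this assay, and the step of a 1.6-fold higher number from compound 1 to compound 3 (0.20 log units; within the scatter) arose from acetyl in place of hydrogen on a nitrogen on an aromatic ring. Compound 2 `Cc1ccc(-c2c(C)c(-c3ccc4c(c3C)CCCO4)c(C(OC(C)(C)C)C(=O)O)c(C)c2NS(C)(=O)=O)cc1C` gives 24000 nM in this assay, the highest number of the set, but its gaps to compound 3 and compound 1 both sit within the scatter.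

Compound 4 `Cc1ccc(-c2c(C)c(-c3ccc4c(c3)CCCO4)c(C(OC(C)(C)C)C(=O)O)c(C)c2NS(C)(=O)=O)cc1C` differs from compound 2 by hydrogen in place of methyl on an aromatic carbon. For the measured compounds named here, no measured step removes a methyl from an aromatic carbon; the only measured step, a 1.6-fold higher number from compound 1 to compound 3 (0.20 log units; within the scatter), was itself within the scatter. The writer therefore expects no shift beyond the scatter in this assay. Compound 4 is estimated at 22000 nM, with a range from 11000 nM to 44000 nM. This estimate means an expected step of a 1.1-fold lower number from compound 2 to compound 4 (0.04 log units; within the scatter).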

Compound 4, half-maximal cytotoxic concentration: 28000 nM
For compound 4 the middle estimate is 1.3-fold (0.10 log units) below the measured one; measured number inside the range.
By their numbers in this assay, from the lowest: compounds 1, 3, 2 and 4 (each within the scatter of the next, the first and the last beyond it).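

Hydrogen in place of methyl on this aromatic carbon, ortho to a fused ring, gives a 1.2-fold higher number from compound 2 to compound 4 (0.07 log units; within the scatter) in this assay and so leaves the number within the scatter. This is the only step shown on a ring carbon rather than on a nitrogen, and in this assay the methyl at this place proves dispensable. No measurement here accounts for this result.

Going by these compounds, whether a fluorine, a methoxy or a longer chain at this place would move the number beyond the scatter stays open.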